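Aryl thiosemicarbazones: halogen swap on the aryl nitrogen

A few compounds are considered here, and "the series" means these few. Any claim that something is new, unique, unknown or untested is made for them only; others in the source may bear on it.

Of the compounds shown here, three have been measured in a functional assay on SGC-7901 cells (Homo sapiens) for antiproliferative activity, read by sulforhodamine B assay, with a stated time of 72 h; a higher number here means a weaker inhibitor, a lower number a stronger inhibitor. Compound 1 `S=C(N/N=C/c1ccc2ccccc2n1)Nc1cccc(Cl)c1` gives 61300 nM and stands second highest of the three numbers. Compound 3 `NC(=S)N/N=C/c1cc2cccnc2s1` gives 100000 nM, a value that sits within the scatter of compound 1. Compound 2 `CC(C)c1cccc(C(C)C)c1NC(=S)N/N=C/c1ccc2ccccc2n1` gives 23500 nM, a lower number that lies beyond the scatter of compound 1. Going by the values given here, no single-point step between measured compounds is available.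

Compound 4 `Fc1ccc(NC(=S)N/N=C/c2ccc3ccccc3n2)cc1` has not been measured. It differs from compound 1 in one place: 4-fluorophenyl in place of 3-chlorophenyl on an amide-type nitrogen. With no measured step of this kind in the series, the change is expected to give no step beyond the scatter in this assay, so a 1.1-fold higher number from compound 1 to compound 4 (0.06 log units; within the scatter) is expected. Compound 4 is thus estimated at 70000 nM, within a range from 30000 nM to 150000 nM.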

Compound 4, half-maximal inhibitory concentration: 32300 nM
Compound 4: middle estimate off by 2.2-fold (0.34 log units), on the high side; low and high end bracket the measured number.
By their numbers in this assay, from the lowest: compounds 2, 4, 1 and 3 (each within the scatter of the next, the first and the last beyond it).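

In this assay, the series gains its first single-place step: 4-fluorophenyl in place of 3-chlorophenyl on an amide-type nitrogen gives a 1.9-fold lower number from compound 1 to compound 4 (0.28 log units; within the scatter) on the shared core. At this position, then, this exchange of one halogenated phenyl for the other produces no step beyond the scatter. No available measurement bears on why the step has this size. The halogen and its place on the ring change together here, so their contributions remain unseparated. Also open, as far as these compounds go, is whether an amine or a carboxylic acid on the phenyl ring would give a step beyond the scatter.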